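Changing the aryl group on the amide of compound 2

A few compounds are considered here, and "the series" means these few. Any claim that something is new, unique, unknown or untested is made for them only; others in the source may bear on it.

In a functional assay on A549 cells (Homo sapiens) for cytotoxicity, read by MTT assay, with a stated time of 72 h (on this read-out higher numbers stand for weaker inhibition and lower numbers for stronger inhibition), compound 2 (`O=C(CN1CCN(c2nnc(Cc3ccncc3)c3ccccc23)CC1)Nc1ccc(F)c(Cl)c1`) gives 12300 nM and so stands level with compound 1 (`O=C(CN1CCN(c2nnc(Cc3ccncc3)c3ccccc23)CC1)Nc1ccc(F)c(C(F)(F)F)c1`) at 16000 nM within the usual scatter. Neither compound can be ranked above the other on these numbers.

Compound 3 (`O=C(CN1CCN(c2nnc(Cc3ccncc3)c3ccccc23)CC1)Nc1cc(C(F)(F)F)ccc1Cl`) alters the group on the amide-type nitrogen, with 2-chloro-5-(trifluoromethyl)phenyl in place of 3-chloro-4-fluorophenyl (2-chloro-5-(trifluoromethyl)phenyl in place of 3-chloro-4-fluorophenyl on an amide-type nitrogen). The rest of the molecule stays the same. The entering group carries a chloro, as compound 2 does, and a trifluoromethyl, as compound 1 does, but the two now sit in a new arrangement on the ring.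

Within the data shown here, only one measured step bears on this change. Chloro replacing trifluoromethyl on an aromatic carbon in compound 2 (a 1.3-fold lower number from compound 1 to compound 2 (0.11 log units; within the scatter)) stayed within the scatter. Among the measured compounds shown here, no measured step tests a new arrangement of groups on this ring, so that guide is only partial, and no clear direction can be drawn from it.

The expected step is therefore small (a 1.1-fold higher number from compound 2 to compound 3 (0.06 log units; within the scatter)), with none expected beyond the scatter in this assay for this change. Compound 3 is estimated at 14000 nM (expected range 6000 nM to 30000 nM).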

Compound 3, half-maximal inhibitory concentration: 1850 nM
The estimate for compound 3 lay 7.6-fold (0.88 log units) above the measured number; the measured number lies below the stated range.
By their numbers in this assay, from the lowest: compound 3; then compounds 2 and 1 (each within the scatter of the next).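

In this assay, the group on the amide-type nitrogen proves able to shift the number well beyond the scatter: 2-chloro-5-(trifluoromethyl)phenyl in place of 3-chloro-4-fluorophenyl gives a 6.6-fold lower number from compound 2 to compound 3 (0.82 log units; beyond the scatter), and in place of 4-fluoro-3-(trifluoromethyl)phenyl it gives an 8.6-fold lower number from compound 1 to compound 3 (0.94 log units; beyond the scatter). Compounds 1 and 2 alone gave no sign of this, as swapping trifluoromethyl for chloro left them level, whereas the new group, which holds both of those substituents on one ring and has no fluoro directly on the ring, separates compound 3 from both. Nothing available here explains why this group gives the lower number.

Which feature of the 2-chloro-5-(trifluoromethyl)phenyl group matters stays open, as the chloro, the trifluoromethyl and the missing ring fluoro all change together in these steps. On these data alone, it is also open how this position would respond to a plain phenyl, or to a ring bearing an amine or a carboxylic acid.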